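The source may hold more compounds than are shown below. What is called first, only, known or untested is meant among the compounds shown, and "the series" means these compounds.

Measured so far in a functional assay on MOLT-4 cells (Homo sapiens) for antiproliferative activity, read by MTT assay, with a stated time of 72 h; a lower number here means a stronger inhibitor, a higher number a weaker inhibitor:
Compound 1 `O=C1C=C(N2CCN(c3ccccc3Cl)CC2)C(=O)c2ccccc21`: > 50000 nM, a limit.
Compound 2 `Cc1ccccc1N1CCN(C2=CC(=O)c3cccc(O)c3C2=O)CC1`: > 50000 nM, a limit.
Compound 3 `O=C1C=C(N2CCC(c3ccccc3)CC2)C(=O)c2c(O)cccc21`: 2700 nM.

Compound 3 is the only one of the three with a number, 2700 nM. Compounds 1 and 2 give no number, and both stand at one reading: the limit of > 50000 nM in this assay, at which 2 of the 3 values shown sit. Among the compounds with values here, no pair among the three forms a measured single-change step, so the series gives no direct measure of what one small substitution does here.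

The next compound is compound 4 `O=C1C=C(N2CCC(c3ccc(Cl)cc3)CC2)C(=O)c2c(O)cccc21`, which differs from compound 3 in one place, phenyl to 4-chlorophenyl: chloro in place of hydrogen on an aromatic carbon. This is chloro in place of hydrogen on an aromatic carbon, para to a large group.

Within the data shown here, the only numerical reference is compound 3 at 2700 nM, and the change is a single atom, so only a modest shift is expected. The expected step of a 1.4-fold lower number from compound 3 to compound 4 (0.13 log units; within the scatter) is small and slightly towards stronger inhibition, and it may well not exceed the usual scatter. A fall to the assay limit is considered possible but unlikely. For compound 4 the expected value is 2000 nM, with an estimated range from 700 nM to 7000 nM.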

Compound 4, half-maximal inhibitory concentration: > 50000 nM
Compound 4 was reported as a limit; the forecaster's own chance of this, stated with the estimate: 8%; at least 25-fold (1.39 log units) between middle value and limit.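

In this assay compound 4 gives > 50000 nM, which is a limit and not a number. This gives the series its first measured single-change step: chloro in place of hydrogen on an aromatic carbon, para to a large group, accounts for an at least 18-fold higher number from compound 3 to compound 4 (1.26 log units; beyond the scatter), so this one place on the phenyl ring is far from indifferent to substitution, and a single added heavy atom is enough to take the reading out of the measurable range. Compound 3 remains the only compound shown with a number, and all the others share one reading: the limit of > 50000 nM in this assay, at which 3 of the 4 values shown sit.

On these data alone, the true size of the step stays open, since only its lower bound can be read, and so does whether the loss is particular to chloro or would follow from any group at this place. Whether a fluoro, a methoxy or an amine at the same position would keep a measurable value, and whether substitution elsewhere on this ring would be tolerated, also remains unanswered by the compounds shown.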